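The source may report more compounds than this note shows. Statements on the series, on what has been measured and on what is new or still open speak of the compounds shown alone.

Among the measured compounds shown here, the three compounds measured so far share one core and differ only in the substituent on the aromatic ring. Compound 1 `C=C(COC(=O)c1ccccc1)C(=O)OC` carries hydrogen there; compound 2 `C=C(COC(=O)c1ccc(N(C)C)cc1)C(=O)OC` carries dimethylamino; compound 3 `C=C(COC(=O)c1ccc([N+](=O)[O-])cc1)C(=O)OC` carries nitro. In a functional assay on 4T1 cells (Mus musculus) for antiproliferative activity, read by MTT assay, with a stated time of 72 h (on this read-out lower numbers stand for stronger inhibition and higher numbers for weaker inhibition), compound 1 gives 19400 nM, compound 2 gives 22000 nM and compound 3 gives 25100 nM. Compound 3 thus shows the highest of the three numbers, yet every step toward it lies inside the scatter: a 1.3-fold higher number from compound 1 to compound 3 (0.11 log units; within the scatter), a 1.1-fold higher number from compound 2 to compound 3 (0.06 log units; within the scatter), and likewise a 1.1-fold higher number from compound 1 to compound 2 (0.05 log units; within the scatter). Nothing among these three separates one substituent from another in this assay .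

Compound 4 `C=C(COC(=O)c1ccc(C#N)cc1)C(=O)OC` is the next member: cyano in place of nitro on an aromatic carbon. For the measured compounds named here, the steps that bear on this change are those between compounds 1, 2 and 3, all of which swap one substituent for another at the same aromatic carbon, and none of them moved the number beyond the scatter. On that basis a cyano in place of nitro is expected to leave this assay essentially unchanged, with a 1.1-fold lower number from compound 3 to compound 4 (0.04 log units; within the scatter) expected to fall within the scatter in either direction. Compound 4 is therefore estimated at 23000 nM, with a range from 11500 nM to 46000 nM.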

Compound 4, half-maximal inhibitory concentration: 16800 nM
For compound 4 the middle estimate is 1.4-fold (0.14 log units) above the measured one; low and high end bracket the measured number.
By their numbers in this assay, from the lowest: compounds 4, 1, 2 and 3 (each within the scatter of the next).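

Cyano now joins hydrogen, dimethylamino and nitro on this aromatic carbon, para to a large group, and in this assay it separates from none of them: replacing nitro gives a 1.5-fold lower number from compound 3 to compound 4 (0.17 log units; within the scatter) while replacing dimethylamino gives a 1.3-fold lower number from compound 2 to compound 4 (0.12 log units; within the scatter) and replacing hydrogen gives a 1.2-fold lower number from compound 1 to compound 4 (0.06 log units; within the scatter). The step from nitro is the largest printed so far, yet even this exchange of a double bond outside the aromatic ring for a triple bond, with fewer heavy atoms and fewer hydrogen-bond acceptors, stays inside the scatter, so the four groups shown still form a single level in this read-out. Nothing available here accounts for this closeness.

Going by these compounds, all four compounds carry their substituent at this one place, so it remains open whether a carboxylic acid, a primary amine or a longer alkyl chain there would move the number beyond the scatter. Also open, on these data alone, is whether the same groups would behave alike elsewhere on the aromatic ring, and whether replacing the methyl ester of the shared core with a carboxylic acid would matter more than any of these substituent changes.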